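Replacing a hydroxyethyl with cyclopropyl on the amide nitrogen

A few compounds are considered here, and "the series" means these few. Any claim that something is new, unique, unknown or untested is made for them only; others in the source may bear on it.

Measured compounds:
compound 1 `CON(Cc1cccs1)C(=O)COc1ccc(C)cc1` gives 10 nM
compound 2 `Cc1ccc(OCC(=O)N(C)Cc2cccs2)cc1` gives 400 nM
compound 3 `Cc1ccc(OCC(=O)N(CCO)Cc2cccs2)cc1` gives 900 nM

All three compounds were tested in an assay on HEK293 cells for agonist activity at transient receptor potential cation channel subfamily M member 8 (Homo sapiens), read by fluorescence and calcium flux, with a stated time of 15 min; a higher number here means that more compound is needed for the effect, a lower number that less compound is needed. Compound 3 stands at the top of the three numbers, so it needs the most compound of the set: it sits a 2.3-fold higher number from compound 2 to compound 3 (0.35 log units; beyond the scatter) and a 90-fold higher number from compound 1 to compound 3 (1.95 log units; beyond the scatter).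

Compound 4 `Cc1ccc(OCC(=O)N(Cc2cccs2)C2CC2)cc1` has not yet been measured. It differs from compound 3 in one place: cyclopropyl in place of 2-hydroxyethyl on an amide-type nitrogen.

Two of the measured steps bear on this. The step of a 90-fold higher number from compound 1 to compound 3 (1.95 log units; beyond the scatter) shows that the methoxy is far more favourable than the 2-hydroxyethyl, and the step of a 2.3-fold higher number from compound 2 to compound 3 (0.35 log units; beyond the scatter) shows that the hydroxymethyl carries a modest penalty over hydrogen. Compound 4 removes the hydroxyl group and keeps a carbon-only group, which is nearer to compound 2 than to compound 1. Going by the values given here, no measured step involves cyclopropyl itself, so the expectation rests on the loss of the hydroxyl alone. A modest step downward is therefore expected for compound 4, roughly a 2.6-fold lower number from compound 3 to compound 4 (0.41 log units; beyond the scatter), bringing it close to compound 2.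

The estimate for compound 4 is 350 nM, with a range from 100 nM to 1200 nM.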

Compound 4, half-maximal effective concentration: 8 nM
Estimate against measurement, compound 4: 44-fold (1.64 log units) above; measured number below the stated range.
By their numbers in this assay, from the lowest: compounds 4 and 1 (each within the scatter of the next); then compound 2; then compound 3.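

In this assay, going by these compounds alone, the amide-type nitrogen turns out to be far more sensitive to the choice of group than the earlier compounds suggested: a 110-fold lower number from compound 3 to compound 4 (2.05 log units; beyond the scatter). Losing the hydroxyl cannot be the whole story, since the methyl group also lacks one, yet a 50-fold lower number from compound 2 to compound 4 (1.70 log units; beyond the scatter); among carbon-only groups at this position, the cyclopropyl ring and the methyl group therefore give very different results. The cyclopropyl group also matches the methoxy group, with a 1.3-fold lower number from compound 1 to compound 4 (0.10 log units; within the scatter), so two quite different groups reach the same level here, and nothing available explains why.

From the compounds shown here alone, it remains open whether the three-membered ring itself is needed. An isopropyl, cyclobutyl or ethoxy group on the same nitrogen could show how far this result extends beyond cyclopropyl and methoxy.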